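The source may report more compounds than this note shows. Statements on the series, on what has been measured and on what is new or still open speak of the compounds shown alone.

Measured in a functional assay on the whole organism (arterial blood) with Rattus norvegicus as the target; on this read-out higher numbers stand for an effect only at larger amounts of compound and lower numbers for an effect already at smaller amounts

compound 1 `COC(=O)NC(CC(=O)N1CCC(n2c(C)nc3cnccc32)CC1)c1ccccc1` gives 0.56 mg/kg
compound 2 `Cc1nc2cnccc2n1CC1CCN(C(=O)C=C(c2ccccc2)c2ccccc2)CC1` gives 0.011 mg/kg
compound 3 `CC/C(=C\C(=O)N1CCC(Cn2c(C)nc3cnccc32)CC1)c1ccccc1` gives 0.0054 mg/kg

Compound 3 has the lowest number of the three, and the gap to each of the others lies beyond the scatter. Compound 2 stands nearest and compound 1 furthest. Compound 4 `COC/C(=C\C(=O)N1CCC(Cn2c(C)nc3cnccc32)CC1)c1ccccc1` has yet to be measured. It carries methoxy in place of methyl on a saturated chain carbon bound to a double-bonded chain carbon, a difference that also reads as ethyl to methoxymethyl. Among the compounds with values here, no two measured compounds differ in one place only, so the data offer no direct precedent for this change, and any forecast is uncertain. Within the data shown here, since compound 3 already has the lowest number so far, a modest move to a higher number is expected in this assay and may not clear the scatter. The expected change is a 1.9-fold higher number from compound 3 to compound 4 (0.27 log units; within the scatter) as a rough estimate. For compound 4 the estimated value is 0.01 mg/kg within an expected range of 0.003 mg/kg to 0.04 mg/kg (the measurement is still to come).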

Compound 4, dose for 50% inhibition: 0.022 mg/kg
Compound 4: middle estimate off by 2.2-fold (0.34 log units), on the low side; the measured number falls inside the stated range.
By their numbers in this assay, from the lowest: compound 3; then compounds 2 and 4 (each within the scatter of the next); then compound 1.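

In this assay, methoxy in place of methyl on a saturated chain carbon bound to a double-bonded chain carbon, which reads as ethyl to methoxymethyl, gives a 4.1-fold higher number from compound 3 to compound 4 (0.61 log units; beyond the scatter). Within the data shown here, this is the first step between measured compounds that differ in one place, and it shows that this position is sensitive to the change, as the number moves beyond the scatter towards larger amounts of compound. Nothing available explains the step.

On these data alone, it remains open whether a longer chain such as propyl, or a hydroxymethyl or aminomethyl group, would give a number nearer that of compound 3 or that of compound 4 at this position. Also open, as far as these compounds go, is whether the same change would give a step of similar size elsewhere on the chain.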